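Notes on the sulfonamide series around compound 1

The source may report more compounds than this note shows. Statements on the series, on what has been measured and on what is new or still open speak of the compounds shown alone.

Compound 1 `O=S(=O)(NCCCNCc1cccc(Cl)c1)c1cc(C(F)(F)F)cc(C(F)(F)F)c1` serves as the reference point of this small set. Within the data shown here, in a functional assay on MIA PaCa-2 cells (Homo sapiens) for inhibition, read by MTT assay, with a stated time of 72 h (on this read-out lower numbers stand for stronger inhibition of growth and higher numbers for weaker inhibition of growth), compound 1 gives 4400 nM, the lower of the two numbers known so far. Compound 2 `O=S(=O)(NCCCCCCNCc1ccc(Br)cc1)c1ccc2ccsc2c1` gives 6000 nM in this assay; the two values lie within the usual scatter of each other, so nothing separates compound 1 from compound 2 on this read-out. Compound 3 `COc1ccc(CNCCCNS(=O)(=O)c2cc(C(F)(F)F)cc(C(F)(F)F)c2)cc1` has not yet been measured. It differs from compound 1 by 4-methoxyphenyl in place of 3-chlorophenyl on a saturated chain carbon bound to an amine nitrogen. Among the measured compounds shown here, no measured pair in the set carries such an exchange, so there is no step from which its effect could be read. For the measured compounds named here, with only two measured compounds, and both close together, the expectation is that the exchange does little: the step of a 1.4-fold higher number from compound 1 to compound 3 (0.13 log units; within the scatter) is expected to stay within the scatter, if anything toward weaker growth inhibition. Compound 3 is estimated at 6000 nM, with a range from 2500 nM to 15000 nM.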

Compound 3, concentration for 50% growth inhibition: 2500 nM
The estimate for compound 3 lay 2.4-fold (0.38 log units) above the measured number, and the stated range covers the measured number.
By their numbers in this assay, from the lowest: compounds 3, 1 and 2 (each within the scatter of the next, the first and the last beyond it).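

In this assay, among these compounds, 4-methoxyphenyl in place of 3-chlorophenyl on a saturated chain carbon bound to an amine nitrogen gives a 1.8-fold lower number from compound 1 to compound 3 (0.25 log units; within the scatter), the first step in the set that can be read at this position. The read-out therefore does not separate the two groups, although the entering group counts one hydrogen-bond acceptor and the leaving group none. Nothing available bears on why this step stays so small.

On these data alone, whether any group at this place would separate from compound 1 remains open, for example an unsubstituted phenyl, a pyridine ring or a carboxylic acid. Also open, as far as these compounds go, is what a longer chain would do on the core of compound 1, since compound 2 differs from it in more than one place.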